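The source may hold more compounds than are shown below. What is called first, only, known or untested is meant among the compounds shown, and "the series" means these compounds.

In a functional assay on SEM cells (Homo sapiens) for cytotoxicity, with a stated time of 72 h (a higher number here means that more compound is needed for the effect, a lower number that less compound is needed), compound 1 `C=C[C@@](C)(/C=C/c1ccc(O)c(/C=C/C#N)c1)CCC=C(C)C` reads > 36600 nM, which is a limit of the assay and not a number. Compound 2 `C=C[C@@](C)(/C=C/c1ccc(O)c(/C=C/C(=O)NCc2ccc(C(F)(F)F)cc2)c1)CCC=C(C)C` reads > 36600 nM, also a limit. Among the measured compounds shown here, compound 3 `COc1ccc(/C=C/[C@@](C)(/C=C/c2ccc(O)c(C=O)c2)CCC=C(C)C)cc1` gives 4550 nM, the only true number among the three. Compound 4 `COc1ccc(/C=C/[C@@](C)(/C=C/c2ccc(O)c(/C=C/C#N)c2)CCC=C(C)C)cc1` has 2-cyanoethenyl in place of formyl on an aromatic carbon, ortho to a hydroxy group (2-cyanoethenyl in place of formyl on an aromatic carbon). For the measured compounds named here, no measured pair shows this change alone. More compound is expected to be needed, because compound 1, which also carries 2-cyanoethenyl but differs elsewhere, stands at > 36600 nM, a limit. The expected step of a 2.6-fold higher number from compound 3 to compound 4 (0.42 log units; beyond the scatter) is modest, and this remains a cautious estimate. For compound 4 the estimated value is 12000 nM, with an expected range from 4000 nM to 36000 nM.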

Compound 4, half-maximal effective concentration: 4540 nM
Beside the measured number, compound 4's estimate is 2.6-fold (0.42 log units) above it; measured number inside the range.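

In this assay, formyl and 2-cyanoethenyl on this aromatic carbon, ortho to a hydroxy group, cannot be told apart when the 2-(4-methoxyphenyl)ethenyl group is present: the swap gives a 1.0-fold lower number from compound 3 to compound 4 (0.00 log units; within the scatter). With 2-cyanoethenyl kept, placing 2-(4-methoxyphenyl)ethenyl instead of vinyl on the saturated chain carbon gives an at least 8.0-fold lower number from compound 1 to compound 4 (0.90 log units; beyond the scatter), so that change counts for far more here. The value of compound 1 is a limit and not a number, so this step has no exact size: the limit of > 36600 nM in this assay, at which 2 of the 4 values shown sit.

From the compounds shown here alone, what an amine or a carboxylic acid would do on this aromatic carbon remains open. So does how the amide side chain of compound 2 would respond to the same 2-(4-methoxyphenyl)ethenyl change.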